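The compounds below may be only part of what the source reports. "The series", "measured", "known", "first", "only" and "open" are said of these compounds alone.

Compound 1, `O=C(O)CCCSCCN1C(=O)CC[C@@H]1/C=C/[C@@H](O)Cc1cccc(N2Cc3ccccc3C2)c1`: > 10000 nM
Compound 2, `O=C(O)CCCSCCN1C(=O)CC[C@@H]1/C=C/[C@@H](O)Cc1cccc(-c2ccc3[nH]ccc3c2)c1`: > 10000 nM
Compound 3, `O=C(O)CCCSCCN1C(=O)CC[C@@H]1/C=C/[C@@H](O)Cc1cccc(-c2nc3ccccc3s2)c1`: > 10000 nM

All three compounds share one core and differ only in the group carried on an aromatic carbon of the terminal ring. In an assay on CHO cells for displacement of a labelled ligand from prostaglandin E2 receptor EP3 subtype (Mus musculus), read by scintillation counting, with a stated time of 60 min (a higher number here means a weaker inhibitor, a lower number a stronger inhibitor), compound 1 reaches only the limit of the assay, > 10000 nM. Compound 2 also gives only a limit in this assay, > 10000 nM. Compound 3 likewise stands at a limit, > 10000 nM. Because every value shown sits at the limit of > 10000 nM in this assay, at which 3 of the 3 values shown sit, none of the steps among them can be read: a step that the two limits leave unreadable from compound 1 to compound 2, a step that the two limits leave unreadable from compound 1 to compound 3 and a step that the two limits leave unreadable from compound 2 to compound 3 are all unreadable in size. Compound 3 therefore has no number of its own, only a limit.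

Compound 4, `O=C(O)CCCSCCN1C(=O)CC[C@@H]1/C=C/[C@@H](O)Cc1cccc(-c2cc3ccccc3o2)c1`, carries the change (1-benzofuran-2-yl in place of 1,3-benzothiazol-2-yl on an aromatic carbon). Among the compounds with values here, the one measured step that bears on it, from compound 3, cannot be read, and the two other steps are equally silent, so no direction beyond the scatter can be expected, and the probable outcome is another limit. Compound 4 is estimated at 15000 nM, between 3000 nM and 100000 nM. This expected step, a step that the limit leaves unreadable from compound 3 to compound 4, is not a readable change.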

Compound 4, inhibition constant: > 10000 nM
Compound 4 gave a limit, no number; the forecaster's own chance of this, stated with the estimate: 80%; the middle value does not contradict the limit.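

Compound 4 also gives only a limit in this assay, > 10000 nM, so none of its steps from compound 1, compound 2 or compound 3 can be read: the limit of > 10000 nM in this assay, at which 4 of the 4 values shown sit.

The compounds shown leave open whether any group at this place gives a measurable value, and how the four groups rank against one another.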